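The compounds below may be only part of what the source reports. "The series", "measured", "known", "first", "only" and "open" are said of these compounds alone.

In a functional assay on PC-3 cells (Homo sapiens) for antiproliferative activity, read by sulforhodamine B assay, with a stated time of 48 h (on this read-out higher numbers stand for weaker inhibition of growth and lower numbers for stronger inhibition of growth), compound 1 (`CCCCCCCC/C=C\CCCCCCCC(=O)N1CCCC1`) gives 13 ug/mL and compound 2 (`CCCCC/C=C\C/C=C\CCCCCCCC(=O)N1CCCCC1`) gives 53.6 ug/mL, so compound 2 holds the higher of the two numbers, a gap beyond the usual scatter. Compound 3 (`CCCCCCCC/C=C\CCCCCCCC(=O)N1CCCCC1`) differs from compound 2 in one place: heptyl in place of hept-1-en-1-yl on a saturated chain carbon bound to a double-bonded chain carbon. Going by the values given here, no measured pair shows this change, so any forecast is uncertain. In this assay the expected step is a modest one toward stronger inhibition of growth, a 2.2-fold lower number from compound 2 to compound 3 (0.35 log units; beyond the scatter). For compound 3 the estimated value is 24 ug/mL, with an expected range of 10 ug/mL to 55 ug/mL.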

Compound 3, concentration for 50% growth inhibition: 8.7 ug/mL
For compound 3 the middle estimate is 2.8-fold (0.44 log units) above the measured one, and the stated range ends above it.
By their numbers in this assay, from the lowest: compounds 3 and 1 (each within the scatter of the next); then compound 2.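

In this assay, heptyl in place of hept-1-en-1-yl on a saturated chain carbon bound to a double-bonded chain carbon gives a 6.2-fold lower number from compound 2 to compound 3 (0.79 log units; beyond the scatter), so this single change in the chain clearly moves the read-out. Piperidin-1-yl in place of pyrrolidin-1-yl on a carbonyl carbon gives a 1.5-fold lower number from compound 1 to compound 3 (0.17 log units; within the scatter), so with this chain the two groups cannot be told apart here. No available measurement bears on why the chain change has this effect. Still open, from the compounds shown here alone, is whether a longer chain, or morpholin-4-yl on the carbonyl carbon, would hold this level of growth inhibition.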